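Stretching the bromoalkyl chain by one more carbon

The compounds below may be only part of what the source reports. "The series", "measured", "known", "first", "only" and "open" are said of these compounds alone.

Compound 1 `O=c1cc(-c2ccccc2)oc2cc(OCCBr)ccc12` gives 127 nM in a functional assay for antagonist activity at Adrenergic receptor alpha-1 (Rattus norvegicus); on this read-out lower numbers stand for tighter binding and higher numbers for weaker binding.
Compound 2 `O=c1cc(-c2ccccc2)oc2cc(OCCCBr)ccc12` gives 390 nM in this assay.
Compound 3 `O=c1cc(-c2ccc(Cl)cc2)oc2cc(OCCCBr)ccc12` gives 679 nM in this assay.

Among these three numbers compound 2 stands second highest; its value and that of compound 3 fall within the scatter of each other, while compound 1 lies below it, beyond the scatter. The unmeasured compound 4 `O=c1cc(-c2ccccc2)oc2cc(OCCCCBr)ccc12` differs from compound 2 in a single place: bromomethyl in place of bromo on a saturated chain carbon, three bonds along the chain from an oxygen on an aromatic ring. Among the measured compounds shown here, the one measured step of the same kind is a 3.1-fold higher number from compound 1 to compound 2 (0.49 log units; beyond the scatter), where lengthening the chain by one carbon moved the number upward. The step of a 1.7-fold higher number from compound 2 to compound 3 (0.24 log units; within the scatter) concerns a different change and does not bear on this one. On that basis the expectation for compound 4 is a modest rise in this assay, perhaps somewhat smaller than before, since the chain is already longer; the expected step is a 1.9-fold higher number from compound 2 to compound 4 (0.28 log units; within the scatter). Compound 4 is therefore estimated at 750 nM, with a range from 300 nM to 1900 nM.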

Compound 4, dissociation constant: 290 nM
Estimate against measurement, compound 4: 2.6-fold (0.41 log units) above; the whole stated range lies above it.
By their numbers in this assay, from the lowest: compound 1; then compounds 4, 2 and 3 (each within the scatter of the next, the first and the last beyond it).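

In this assay the change from the 3-bromopropyl chain to the 4-bromobutyl chain gives a 1.3-fold lower number from compound 2 to compound 4 (0.13 log units; within the scatter) and so does not repeat the rise seen one carbon earlier (a 3.1-fold higher number from compound 1 to compound 2 (0.49 log units; beyond the scatter)). The longest chain still stands apart from the shortest, with a 2.3-fold higher number from compound 1 to compound 4 (0.36 log units; beyond the scatter), so among these compounds the clear change comes with the first added carbon, and the two longer chains cannot be told apart. No evidence is available to explain this levelling off.

As far as these compounds go, whether a longer chain than 4-bromobutyl would stay level or move the number again remains open. From the compounds shown here alone, it is also open what an amine in place of the bromo group would do, and whether the chloro group of compound 3 would behave the same way on another chain length.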